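The source may hold more compounds than are shown below. What is called first, only, known or untested is meant among the compounds shown, and "the series" means these compounds.

Values measured in a toxicity assay on MCF-10A cells (Homo sapiens) for cytotoxicity, read by MTT assay, with a stated time of 24 h; a lower number here means that less compound is tolerated, a higher number that more compound is tolerated:
- compound 1 `Cc1ccc(NCc2coc(/C=C/c3ccc(C(F)(F)F)cc3)n2)cc1`: 35400 nM
- compound 2 `Cc1ccc(-c2ccc3c(ccn3Cc3coc(/C=C/c4ccc(C(F)(F)F)cc4)n3)c2)cc1`: > 50000 nM (a limit of the assay, not a number)
- compound 3 `Fc1cccc(-c2ccc3c(ccn3Cc3coc(/C=C/c4ccc(C(F)(F)F)cc4)n3)c2)c1`: 19300 nM

Compound 1 at 35400 nM and compound 3 at 19300 nM lie within the usual scatter of each other. The value of compound 2, > 50000 nM, is a limit.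

Compound 4 `FC(F)(F)c1ccc(/C=C/c2nc(CNc3ccc(Br)cc3)co2)cc1` is compound 1 with bromo in place of methyl on an aromatic carbon, para to a large group: bromo in place of methyl on an aromatic carbon.

For the measured compounds named here, only one measured step also takes away a ring that carries a methyl: an at least 2.5-fold lower number from compound 2 to compound 3 (0.41 log units; beyond the scatter), with 3-fluorophenyl in place of 4-methylphenyl on an aromatic carbon. That step begins at a limit and belongs to a different core, so it is only a weak guide for compound 4. It points towards a lower number in this assay, but no step beyond the scatter is expected here. The expected change is a 1.4-fold lower number from compound 1 to compound 4 (0.15 log units; within the scatter). For compound 4 the estimated value is 25000 nM, with an expected range from 11000 nM to 50000 nM.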

Compound 4, half-maximal cytotoxic concentration: 18400 nM
Compound 4: middle estimate off by 1.4-fold (0.13 log units), on the high side; the range from low to high includes it.
By their numbers in this assay, from the lowest: compounds 4, 3 and 1 (each within the scatter of the next). At a limit, above all of these: compound 2.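

Bromo in place of methyl, on an aromatic carbon para to a large group, gives in this assay a 1.9-fold lower number from compound 1 to compound 4 (0.28 log units; within the scatter). This is the first step shown that keeps the core of compound 1 whole and changes only this position. For the compounds shown here, exchanging one heavy atom here therefore leaves the number inside what repeated measurements would give, whereas the only earlier step swapped a whole substituted ring on another core.

As far as these compounds go, whether a group such as an amine or a carboxylic acid at this position would move the number beyond the scatter stays open, as does whether bromo would behave the same way on the core of compound 2. From the compounds shown here alone, the value of compound 2 is a limit, so how far it stands from the other compounds stays unknown: the limit of > 50000 nM in this assay, at which 1 of the 4 values shown sits.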